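The source may report more compounds than this note shows. Statements on the series, on what has been measured and on what is new or still open speak of the compounds shown alone.

Measured so far in a functional assay on SK-OV-3 cells (Homo sapiens) for antiproliferative activity, read by MTT assay, with a stated time of 72 h; on this read-out lower numbers stand for stronger inhibition and higher numbers for weaker inhibition:
- compound 1 `O=C(CCc1cccc2c1B(O)OC2)Nc1cccc(-c2cccc(F)c2)c1` gives 480 nM
- compound 2 `O=C(CCc1cccc2c1B(O)OC2)Nc1cccc(-c2ccc(Cl)cc2)c1` gives 220 nM

Compound 2 stands lowest of these two numbers. The next change leads to compound 3 `COc1cc(OC)cc(-c2cccc(NC(=O)CCc3cccc4c3B(O)OC4)c2)c1` and is as follows (3,5-dimethoxyphenyl in place of 4-chlorophenyl on an aromatic carbon). Among the measured compounds shown here, the only measured step (a 2.2-fold lower number from compound 1 to compound 2 (0.34 log units; beyond the scatter)) was modest and also exchanged the phenyl group on an aromatic carbon. For the measured compounds named here, no measured compound carries a methoxy group, so the direction is uncertain. A step no larger than that one is expected in this assay, leaning toward a higher number. The estimated step is small (a 1.8-fold higher number from compound 2 to compound 3 (0.26 log units; within the scatter)). For compound 3 the estimated value is 400 nM (expected range 130 nM to 1200 nM).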

Compound 3, half-maximal inhibitory concentration: 44 nM
The estimate for compound 3 lay 9.1-fold (0.96 log units) above the measured number, and the stated range ends above it.
By their numbers in this assay, from the lowest: compound 3; then compound 2; then compound 1.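

In this assay, this aromatic carbon responds more strongly to the attached phenyl group than the halogen-bearing pair suggested: 3,5-dimethoxyphenyl gives a 5.0-fold lower number from compound 2 to compound 3 (0.70 log units; beyond the scatter) and an 11-fold lower number from compound 1 to compound 3 (1.04 log units; beyond the scatter). The entering group brings hydrogen-bond acceptors, while the 4-chlorophenyl group it replaces has none, but this difference is only a count and does not establish what drives the gain. Nothing available accounts for the change in potency.

As far as these compounds go, it remains open whether one methoxy group would suffice or both are needed. Also open, from the compounds shown here alone, is whether a hydroxyl group or an amine in place of methoxy would hold the gain.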